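Trimming the Amino Chain on the Shared Core

The compounds below may be only part of what the source reports. "The series", "measured", "known", "first", "only" and "open" are said of these compounds alone.

Compound 1, `CNc1nc(NCc2ccc(NC(=O)c3ccc(F)cc3)cc2)c2ccccc2n1`, carries a methylamino group on the shared core and a fluorine on the benzamide ring; in a functional assay on SW480 cells (Homo sapiens) for inhibition, read by luminescence and resazurin assay, with a stated time of 3 days (on this read-out lower numbers stand for stronger inhibition and higher numbers for weaker inhibition), compound 1 gives 2000 nM. Compound 2, `CN(C)CCCNc1nc(NCc2ccc(NC(=O)c3ccc(CN4CCN(C)CC4)cc3)cc2)c2ccccc2n1`, differs from it at two places: a longer amino chain on the core and a methylpiperazinylmethyl group on the benzamide ring. In this assay compound 2 reaches only > 20000 nM, which is a limit of the assay rather than a measured number, so compound 2 stands at the limit of > 20000 nM in this assay, at which 1 of the 2 values shown sits.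

Compound 3, `CNc1nc(NCc2ccc(NC(=O)c3ccc(CN4CCN(C)CC4)cc3)cc2)c2ccccc2n1`, keeps the benzamide side of compound 2 and alters only the chain on the core: hydrogen in place of 2-(dimethylamino)ethyl on a saturated chain carbon bound to a nitrogen on an aromatic ring. Within the data shown here, no measured pair differs in exactly this way, so the size of the step cannot be read from the data. Among the measured compounds shown here, compound 1, the only compound with the methylamino group, gives 2000 nM, but compound 1 also differs on the benzamide ring, so the two changes cannot be separated. The step from compound 2 to compound 3 is nonetheless expected to run toward stronger inhibition, as an at least 2.5-fold lower number from compound 2 to compound 3 (0.39 log units; beyond the scatter). Compound 3 is estimated at 8000 nM, with a likely range from 2000 nM to 30000 nM.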

Compound 3, half-maximal inhibitory concentration: 11000 nM
Compound 3: the middle estimate sits 1.4-fold (0.14 log units) below what was measured; low and high end bracket the measured number.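

Holding the benzamide side fixed, putting methyl in place of 3-(dimethylamino)propyl on the amino group of the shared core gives an at least 1.8-fold lower number from compound 2 to compound 3 (0.25 log units; that floor lies within the scatter) in this assay and so provides the first reading of this chain change alone, though only as a floor. Compound 2 stands at a limit and not at a number: the limit of > 20000 nM in this assay, at which 1 of the 3 values shown sits. With the methylamino group held fixed, the other new comparison isolates the benzamide ring, where (4-methylpiperazin-1-yl)methyl in place of fluoro gives a 5.5-fold higher number from compound 1 to compound 3 (0.74 log units; beyond the scatter) and shows that this ring change alone moves the read-out toward weaker inhibition, something the two earlier compounds could not separate from the chain change.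

As far as these compounds go, whether the chain's length or its dimethylamino end matters more stays open, and a plain propyl chain or a shorter ethyl group on the same amino nitrogen would help to separate the two. From the compounds shown here alone, it is also open whether the step seen on the benzamide ring would hold with other groups there, such as a morpholine in place of the methylpiperazine, or with the longer chain on the core.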